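The compounds below may be only part of what the source reports. "The series", "measured", "known", "first", "only" and "open" are said of these compounds alone.

Compound 1 `C/C=C1/[C@H](O[C@@H]2O[C@H](CO)[C@@H](O)[C@H](O)[C@H]2O)OC=C(C(=O)OC)[C@H]1CC(=O)NCCC` is a propylamide on the shared core with an unprotected sugar. In a functional assay on SK-BR-3 cells (Homo sapiens) for antiproliferative activity, read by MTT assay, with a stated time of 72 h (on this read-out lower numbers stand for stronger inhibition and higher numbers for weaker inhibition), compound 1 returns only a limit, > 20000 nM, so on the numbers shown it stands at the weak end without a value of its own. Compound 2 `C/C=C1/[C@H](O[C@@H]2O[C@H](COC(C)=O)[C@@H](OC(C)=O)[C@H](OC(C)=O)[C@H]2OC(C)=O)OC=C(C(=O)OC)[C@H]1CC(=O)OCCCCCCCCCCCCCCC`, with an acetylated sugar and a long-chain ester, gives 3810 nM in this assay. Compound 3 `C/C=C1/[C@H](O[C@@H]2O[C@H](COC(C)=O)[C@@H](OC(C)=O)[C@H](OC(C)=O)[C@H]2OC(C)=O)OC=C(C(=O)OC)[C@H]1CC(=O)OCC`, the acetylated ethyl ester, gives only a limit, > 15000 nM. Compound 4 `C/C=C1/[C@H](O[C@@H]2O[C@H](CO)[C@@H](O)[C@H](O)[C@H]2O)OC=C(C(=O)OC)[C@H]1CC(=O)OCCc1ccccc1` is the unmeasured ester on the free sugar; the change from compound 1 is phenethyloxy in place of propylamino on a carbonyl carbon. Among the measured compounds shown here, no single-point step exists among the measured pairs; compound 2 and compound 3 show one value and one limit. Compound 4 is expected to move modestly toward stronger inhibition, an at least 1.6-fold lower number from compound 1 to compound 4 (0.22 log units; that floor lies within the scatter), though a limit may again be reported. The estimate for compound 4 is 12000 nM, between 3000 nM and 40000 nM.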

Compound 4, half-maximal inhibitory concentration: 11000 nM
Compound 4: the middle estimate sits 1.1-fold (0.04 log units) above what was measured, within the range that was stated.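

In this assay the free-sugar compounds now include a value of their own, as compound 4 gives 11000 nM. Phenethyloxy in place of propylamino on a carbonyl carbon provides the first readable step in the series, an at least 1.8-fold lower number from compound 1 to compound 4 (0.25 log units; that floor lies within the scatter). That step is only a floor because compound 1 stands at a limit: the limit of > 20000 nM in this assay, at which 1 of the 4 values shown sits.

Still open, as far as these compounds go, is whether the aromatic ring or the ester link carries the step, which a propyl ester or a phenethyl amide on the free sugar would separate. Also open, from the compounds shown here alone, is how phenethyloxy reads on the acetylated sugar.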